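A few compounds are considered here, and "the series" means these few. Any claim that something is new, unique, unknown or untested is made for them only; others in the source may bear on it.

In an ADME assay on cells (Macrophage, Mus musculus) for cytotoxicity (on this read-out higher numbers stand for lower toxicity in this test and lower numbers for higher toxicity in this test), compound 1 `Nc1ncnc2c([C@@H]3O[C@H](CO)[C@@H](O)[C@H]3O)cn(-c3ccc(Cl)cc3)c12` reads > 64000 nM, which is a limit of the assay and not a number. Compound 3 `O=c1[nH]cnn2c([C@@H]3O[C@H](CO)[C@@H](O)[C@H]3O)cnc12` reads > 64000 nM, again a limit. Compound 2 `Nc1ncnn2c([C@@H]3O[C@H](CO)[C@@H](O)[C@H]3O)cnc12` gives a number, 32000 nM. Compound 1 thus stands at the limit of > 64000 nM in this assay, at which 2 of the 3 values shown sit. Compound 4 `Nc1ncnc2c([C@@H]3O[C@H](CO)[C@@H](O)[C@H]3O)cn(-c3ccc(Br)cc3)c12` differs from compound 1 by bromo in place of chloro on an aromatic carbon, para to a large group. Within the data shown here, no measured pair here differs in one place alone, so this change has no direct precedent. The expected step of a number no higher from compound 1 to compound 4 (the limit leaves the size open) is none beyond the scatter, with no direction foreseen. For compound 4 the estimate is 64000 nM, with an expected range of 30000 nM to 128000 nM.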

Compound 4, half-maximal cytotoxic concentration: > 64000 nM
Compound 4: only a limit was reported (the forecaster's own chance of this, stated with the estimate: 75%); the middle value lies on the limit itself.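

Compound 1 and compound 4 both report only a limit of the assay and not a number, so no step between them can be read: the limit of > 64000 nM in this assay, at which 3 of the 4 values shown sit.

The compounds shown leave open whether bromo in place of chloro changes cytotoxicity at all.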